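The source may report more compounds than this note shows. Statements on the series, on what has been measured and on what is new or still open speak of the compounds shown alone.

Compounds measured in an assay on isolated protein for binding affinity to adenosine receptor A1 (Bos taurus); on this read-out higher numbers stand for weaker inhibition and lower numbers for stronger inhibition:

- compound 1 `CNc1nc(-c2ccccc2)nc2c1nnn2Cc1ccccc1Cl`: 191000000 nM
- compound 2 `OCCCNc1nc(-c2ccccc2)nc2c1nnn2Cc1ccccc1Cl`: 33000000 nM
- compound 3 `CNc1nc(-c2ccccc2)nc2c1nnn2Cc1ccccc1F`: 25000000 nM

Compound 3 gives the lowest number of the three in this assay, but its gap to compound 2 falls within the scatter, so the two cannot be ordered; only the gap to compound 1 is beyond the scatter, the step being a 7.6-fold lower number from compound 1 to compound 3 (0.88 log units; beyond the scatter).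

Compound 4 `CCNc1nc(-c2ccccc2)nc2c1nnn2Cc1ccccc1F` differs from compound 3 by methyl in place of hydrogen on a saturated chain carbon bound to a nitrogen on an aromatic ring. Among the compounds with values here, only one measured step touches the same place: a 5.8-fold lower number from compound 1 to compound 2 (0.76 log units; beyond the scatter), where a larger group enters there. That step was modest, and the group now entering is smaller, so in this assay a step of at most modest size toward lower numbers, or none beyond the scatter, is expected for compound 4; an estimated step of a 1.7-fold lower number from compound 3 to compound 4 (0.22 log units; within the scatter) seems reasonable on these few points. Compound 4 is therefore expected at 15000000 nM, with a range from 5000000 nM to 50000000 nM.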

Compound 4, inhibition constant: 11000000 nM
Compound 4: the middle estimate sits 1.4-fold (0.13 log units) above what was measured, within the range that was stated.
By their numbers in this assay, from the lowest: compound 4; then compounds 3 and 2 (each within the scatter of the next); then compound 1.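

In this assay, methylamino to ethylamino gives a 2.3-fold lower number from compound 3 to compound 4 (0.36 log units; beyond the scatter) on the fluoro compound, so even the entry of methyl at this place moves the number beyond the scatter. Until now this place had been read only with 2-hydroxyethyl entering and with chloro on the aromatic ring; the direction toward lower numbers now also holds with fluoro there and with an entering group that has 0 hydrogen-bond donors and 0 hydrogen-bond acceptors. No measured evidence here bears on why the number falls at this place.

As far as these compounds go, whether a longer chain such as propyl or butyl continues this direction remains open. Also open, from the compounds shown here alone, is how much of the step seen with 2-hydroxyethyl belongs to its chain and how much to its hydroxyl, since the ethylamino and 2-hydroxyethyl groups have not been read on the same aromatic substituent.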